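One Methyl Added to the Amide Chain of Compound 1

The compounds below may be only part of what the source reports. "The series", "measured", "known", "first", "only" and "open" are said of these compounds alone.

Within the data shown here, compound 1 `CCC(=O)N(Cc1ccc(OC)c(O)c1)c1cc(OC)c(OC)c(OC)c1` is the only compound here with a numerical result: in a functional assay on HCT-116 cells (Homo sapiens) for inhibition, read by MTT assay, with a stated time of 48 h (on this read-out lower numbers stand for stronger inhibition and higher numbers for weaker inhibition), compound 1 gives 61 nM. Compound 2 `COc1cc(NCc2ccccc2)cc(OC)c1OC` reaches only the limit of the assay, giving > 80000 nM in this assay. Compound 3 `COc1cc(NCc2ccc(Br)cc2)cc(OC)c1OC` likewise sits at the assay limit, with > 80000 nM in this assay. The step that the two limits leave unreadable from compound 2 to compound 3 therefore cannot be read, as both values rest on (the limit of > 80000 nM in this assay, at which 2 of the 3 values shown sit). Compound 4 `COc1ccc(CN(C(=O)C(C)C)c2cc(OC)c(OC)c(OC)c2)cc1O` differs from compound 1 by methyl in place of hydrogen on a saturated chain carbon bound to a carbonyl carbon and a saturated chain carbon, that is, ethyl to isopropyl, propanoyl to isopropylcarbonyl. Among the measured compounds shown here, no measured step touches this part of the molecule, so the data give no direction for it. The expected change is a 1.0-fold lower number from compound 1 to compound 4 (0.01 log units; within the scatter), within the usual scatter. Compound 4 is therefore estimated at 60 nM, between 20 nM and 200 nM.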

Compound 4, half-maximal inhibitory concentration: 310 nM
The estimate for compound 4 lay 5.2-fold (0.71 log units) below the measured number; the measured number lies above the stated range.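

The propanoyl chain of compound 1 does not tolerate even this small change freely: in this assay, one added methyl on the saturated chain carbon bound to the carbonyl carbon gives a 5.1-fold higher number from compound 1 to compound 4 (0.71 log units; beyond the scatter), which means weaker inhibition. This is the first readable step among the compounds shown, and it shows that this part of the molecule matters. Nothing measured here accounts for the change. From the compounds shown here alone, whether a shorter acetyl chain, a longer butanoyl chain or a cyclopropyl group on the carbonyl would do better or worse remains open.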